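Moving a Ring Nitrogen within a Fused Bicyclic Group

The compounds below may be only part of what the source reports. "The series", "measured", "known", "first", "only" and "open" are said of these compounds alone.

Compound 3 `CCOC(=O)C1=C(Nc2ccccc2)S/C(=C\c2cc3cnccc3[nH]2)C1=O` is one of three analogues measured in a functional assay on JAR cells (Homo sapiens) for inhibition, read by MTT assay, with a stated time of 72 h, tested at 10 uM (on this read-out lower numbers stand for less inhibition and higher numbers for more inhibition at the one concentration tested (going by the name of the read-out)), sharing its core with compound 1 `CCOC(=O)C1=C(Nc2ccccc2)S/C(=C\c2cc[nH]c2)C1=O` and compound 2 `CCOC(=O)C1=C(Nc2ccccc2)S/C(=C\c2cc3cccnc3[nH]2)C1=O`. In this assay compound 1 gives 19.5% and compound 2 gives 54.3%. For compound 3 the assay reports only a limit, < 10%, not a number; this is the limit of < 10% in this assay, at which 1 of the 3 values shown sits. Compound 4 `CCOC(=O)C1=C(Nc2ccccc2)S/C(=C\c2cc3ncccc3[nH]2)C1=O` has the same atoms as compound 3, joined differently: a group of 9 heavy atoms (7 carbon, 2 nitrogen; one five-membered aromatic ring with 1 hetero atom, one six-membered aromatic ring with 1 hetero atom) in place of a group of 9 heavy atoms (7 carbon, 2 nitrogen; one five-membered aromatic ring with 1 hetero atom, one six-membered aromatic ring with 1 hetero atom), on a double-bonded chain carbon bound to a double-bonded ring carbon. The step that bears on this is a number at least 44.3 percentage points lower from compound 2 to compound 3 (beyond the scatter), showing that rearranging this fused group can move the read-out strongly; a number at least 9.5 percentage points lower from compound 1 to compound 3 (that floor lies within the scatter) was smaller. Since compound 3 sits at a limit, the size of the change is uncertain, but an upward move is expected. Compound 4 is estimated at 25%, between 5% and 55%. That would mean an expected a number at least 15 percentage points higher from compound 3 to compound 4 (beyond the scatter).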

Compound 4, a percentage reported as inhibition, at one concentration (the size of the read-out at that concentration, not a potency): 74.8%
Estimate against measurement, compound 4: 49.8 percentage points below; the measured number lies above the stated range.
By their numbers in this assay, from the lowest: compound 1; then compound 2; then compound 4. At a limit, below all of these: compound 3.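

Among groups with the same atoms, joined differently, the read-out in this assay can swing widely, with a number at least 64.8 percentage points higher from compound 3 to compound 4 (beyond the scatter). Compounds 2 and 3 showed only a fall on such a rearrangement, whereas this one gives a rise, with a number 20.5 percentage points higher from compound 2 to compound 4 (beyond the scatter). The fused group in place of the single five-membered ring now gives a number 55.3 percentage points higher from compound 1 to compound 4 (beyond the scatter), so the earlier gain with compound 2 was not the largest this change can give.

Compound 3 remains a limit rather than a number: the limit of < 10% in this assay, at which 1 of the 4 values shown sits. As far as these compounds go, whether an amine or a methoxy group on the fused group would keep this read-out remains open.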